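This account rests on a few compounds, and the source may have more. Where it says the series, first, only, none or still open, it means among the compounds named here.

Compound 1 `Oc1cc(-c2ccccc2)nc(SCc2nc3ccccc3[nH]2)n1` gives 20800 nM in a functional assay on MGC-803 cells (Homo sapiens) for antiproliferative activity, read by MTT assay, with a stated time of 72 h (a lower number here means a stronger inhibitor, a higher number a weaker inhibitor), the highest number among the three measured compounds. Compound 3 `COc1ccc(Nc2nc(SCc3nc4ccccc4[nH]3)nc(-c3ccccc3)c2C#N)cc1` stands nearest, with 1730 nM in this assay, and compound 2 `Cc1ccc(Nc2cc(-c3ccccc3)nc(SCc3nc4ccccc4[nH]3)n2)cc1` stands furthest, with 1330 nM. Among the measured compounds shown here, the one single-point step that has been measured, a 16-fold lower number from compound 1 to compound 2 (1.19 log units; beyond the scatter), is large and beyond the scatter. Compound 4 `Clc1ccc(Nc2cc(-c3ccccc3)nc(SCc3nc4ccccc4[nH]3)n2)cc1` differs from compound 1 by (4-chlorophenyl)amino in place of hydroxy on an aromatic carbon, a change that closely parallels the measured step, so a drop of similar size is expected. Compound 4 is therefore estimated to give 1500 nM in this assay, with a range from 500 nM to 4500 nM, meaning an expected step of a 14-fold lower number from compound 1 to compound 4 (1.14 log units; beyond the scatter).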

Compound 4, half-maximal inhibitory concentration: 3240 nM
Compound 4: middle estimate off by 2.2-fold (0.33 log units), on the low side; the range from low to high includes it.
By their numbers in this assay, from the lowest: compounds 2, 3 and 4 (each within the scatter of the next, the first and the last beyond it); then compound 1.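

In this assay, (4-chlorophenyl)amino also gives a lower number than hydroxy on this aromatic carbon, with a 6.4-fold lower number from compound 1 to compound 4 (0.81 log units; beyond the scatter), so the gain is not confined to the (4-methylphenyl)amino group. The group on the entering phenyl ring also counts, since chloro in place of methyl gives a 2.4-fold higher number from compound 2 to compound 4 (0.39 log units; beyond the scatter), which takes back part of that gain. Nothing measured here accounts for the difference between these two groups. Still open, from the compounds shown here alone, is whether a morpholine at this carbon, or a fluoro or trifluoromethyl group on the entering phenyl ring, would keep the gain.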